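The compounds below may be only part of what the source reports. "The series", "measured", "known", "first", "only" and "open" are said of these compounds alone.

Measured so far in a functional assay on HEK293 cells for agonist activity at melatonin receptor type 1B (Homo sapiens), read by calcium flux; a higher number here means that more compound is needed for the effect, a lower number that less compound is needed:
compound 1, `COc1cc2c(CN)coc2cc1C`: 350000 nM
compound 2, `CCN(CC)Cc1coc2cc(C)c(OC)cc12`: 360000 nM

Going by the values given here, compound 2 stands highest of the two numbers in this assay, with compound 1 its only neighbour, and the gap between them lies within the scatter. Among the compounds with values here, the one recorded step, a 1.0-fold higher number from compound 1 to compound 2 (0.01 log units; within the scatter), therefore carries no direction of its own.

Compound 3, `COc1cc2c(CN3CCCC3)coc2cc1C`, is the next member. It differs from compound 2 in one place: pyrrolidin-1-yl in place of diethylamino on a saturated chain carbon bound to an aromatic carbon. Within the data shown here, the only measured step that bears on this change is the earlier exchange of amine substituents on that same chain carbon, a 1.0-fold higher number from compound 1 to compound 2 (0.01 log units; within the scatter), which left the number essentially where it was. The move from compound 2 to compound 3 is a further change at the same position, so no movement beyond the scatter is expected in this assay. The step is estimated as a 1.0-fold lower number from compound 2 to compound 3 (0.01 log units; within the scatter). Compound 3 is expected to give 350000 nM in this assay, with a range from 150000 nM to 800000 nM. Going by these compounds, whether this weak activity is returned as a number or only as a limit of the assay remains open.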

Compound 3, half-maximal effective concentration: 350000 nM
Estimate against measurement, compound 3: no gap at the digits printed, within the range that was stated.
By their numbers in this assay, from the lowest: compounds 1, 3 and 2 (each within the scatter of the next).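

In this assay, the exchange of diethylamino for pyrrolidin-1-yl on a saturated chain carbon bound to an aromatic carbon reads a 1.0-fold lower number from compound 2 to compound 3 (0.01 log units; within the scatter), and the exchange of amino for pyrrolidin-1-yl at the same place reads no change at the digits printed from compound 1 to compound 3 (within the scatter). The earlier pair covered only open groups on this carbon; the series now includes a five-membered non-aromatic ring as well, and with the same count of heavy atoms as diethylamino, that ring leaves the number within the scatter. Across amino, diethylamino and pyrrolidin-1-yl, all three steps at this place lie within the scatter, so these compounds give no ordering of the three groups, and no available measurement bears on why their numbers stay together.

Still open, going by these compounds, is whether a group of another kind on this carbon, such as a carboxylic acid or a morpholine ring, or a longer chain between the shared core and the amine, would produce a step beyond the scatter. The compounds shown also leave open whether replacing the methoxy or methyl group on the shared core would do so.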